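A Second Aryl Swap at the Same Ring Position

The source may hold more compounds than are shown below. What is called first, only, known or untested is meant among the compounds shown, and "the series" means these compounds.

Compound 1, `COc1ccc(-c2cc3nccc(-c4cc(OC)c(OC)c(OC)c4)n3n2)cc1F`, was tested in a functional assay on B16-F0 cells (Mus musculus) for inhibition, read by CCK-8 assay, with a stated time of 48 h (a higher number here means a weaker inhibitor, a lower number a stronger inhibitor), where compound 1 gives 3950 nM. Compound 2, `COc1cc(-c2ccnc3cc(-c4cccc(C#N)c4)nn23)cc(OC)c1OC`, differs from compound 1 only in the aryl group on one aromatic carbon. In this assay compound 2 gives > 10000 nM, which is a limit of the assay rather than a measured number, as recorded in the limit of > 10000 nM in this assay, at which 1 of the 2 values shown sits. The step of an at least 2.5-fold higher number from compound 1 to compound 2 (0.40 log units; beyond the scatter) is therefore known only as a minimum. Compound 3, `COc1cc(-c2ccnc3cc(-c4ccc(C(F)(F)F)cc4)nn23)cc(OC)c1OC`, alters the same aryl group once more: 4-(trifluoromethyl)phenyl in place of 3-cyanophenyl on an aromatic carbon. Among the compounds with values here, the only measured step at this position, from compound 1 to compound 2, points toward weaker inhibition, and no step starting from compound 2 has been measured, so compound 3 is expected to remain close to that limit. Compound 3 is thus expected to give an estimated 10000 nM, with a range from 3000 nM to 30000 nM, a step of a number no higher from compound 2 to compound 3 (the limit leaves the size open) expected to stay within the scatter.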

Compound 3, half-maximal inhibitory concentration: 1770 nM
Estimate against measurement, compound 3: 5.6-fold (0.75 log units) above, and the stated range ends above it.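

Changing the aryl group at this position can also strengthen inhibition, not only weaken it, in this assay: the change to 4-(trifluoromethyl)phenyl gives an at least 5.6-fold lower number from compound 2 to compound 3 (0.75 log units; beyond the scatter), and it also gives a 2.2-fold lower number from compound 1 to compound 3 (0.35 log units; beyond the scatter). The aryl group on this carbon of the five-membered aromatic ring can therefore move the result in either direction, and compound 3 is the strongest of the three, with its steps to both others beyond the scatter. The first of those steps is only a minimum, because compound 2 stands at a limit of the assay rather than at a number: the limit of > 10000 nM in this assay, at which 1 of the 3 values shown sits.

On these data alone, whether the gain belongs to the trifluoromethyl group itself or to where it sits on the phenyl ring stays open, as the group and its place change together here. As far as these compounds go, how an unsubstituted phenyl ring, an amine or a carboxylic acid would behave on this carbon also remains unknown.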